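The compounds below may be only part of what the source reports. "The series", "measured", "known", "first", "only" and "open" are said of these compounds alone.

Working notes on the series. In a functional assay on THP-1 cells (Homo sapiens) for inhibition (a lower number here means a stronger inhibitor of growth, a higher number a weaker inhibitor of growth), compound 1 (`Cc1noc(C)c1-c1ccc2c(c1)c(CCc1ccccc1)cn2CCCCCC(=O)NO`) gives 15500 nM, compound 2 (`Cc1noc(C)c1-c1ccc2c(c1)c(CCc1ccc(F)cc1)cn2CCCCCC(=O)NO`) gives 15500 nM, and compound 3 (`Cc1noc(C)c1-c1ccc2c(c1)c(CCc1ccc(F)cc1)cn2CCCCCCC(=O)NO`) gives 15500 nM, so compound 3 stands level with the other two.

The next structure is compound 4 (`Cc1cccc(Cc2cn(CCCCCCC(=O)NO)c3ccc(-c4c(C)noc4C)cc23)c1`). Its difference from compound 3 is as follows: 3-methylphenyl in place of 4-fluorobenzyl on a saturated chain carbon bound to an aromatic carbon. Cut one bond further out, the same difference reads 2-(4-fluorophenyl)ethyl to 3-methylbenzyl.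

Going by the values given here, two measured steps bear on this. Fluoro in place of hydrogen on an aromatic carbon gave no change at the digits printed from compound 1 to compound 2 (within the scatter). The change at the hydroxycarbamoyl end of the chain gave no change at the digits printed from compound 2 to compound 3 (within the scatter). Neither step goes beyond the scatter, but neither is the same change as the one now in question, so the evidence is indirect.

Given the flat values, with compound 3 at 15500 nM, no shift beyond the scatter is expected in this assay, and no direction is favoured. The estimated change is a 1.0-fold lower number from compound 3 to compound 4 (0.01 log units; within the scatter). For compound 4 the expected value is 15000 nM, with an estimated range of 6000 nM to 25000 nM.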

Compound 4, concentration for 50% growth inhibition: 15500 nM
The estimate for compound 4 lay 1.0-fold (0.01 log units) below the measured number; the range from low to high includes it.
By their numbers in this assay, from the lowest: compounds 1, 2, 3 and 4 (each within the scatter of the next).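

In this assay, 3-methylphenyl in place of 4-fluorobenzyl on a saturated chain carbon bound to an aromatic carbon gave no change at the digits printed from compound 3 to compound 4 (within the scatter). Read one bond further out, this step replaces the whole 2-(4-fluorophenyl)ethyl group with 3-methylbenzyl, so the flat read-out now covers a change of the entire group at this position, where the earlier steps showed only a fluoro on its ring and a change at the hydroxycarbamoyl end of the chain. No measurement on hand accounts for this flat result.

On these data alone, whether an amine or a carboxylic acid at this position would move the number remains open. So does the effect of a carboxylic acid in place of the hydroxycarbamoyl, and the compounds shown do not tell which part of the structure, if any, governs the number in this assay.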